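A few compounds are considered here, and "the series" means these few. Any claim that something is new, unique, unknown or untested is made for them only; others in the source may bear on it.

Measured so far in a functional assay on MCF7 cells (Homo sapiens) for inhibition; on this read-out lower numbers stand for stronger inhibition and higher numbers for weaker inhibition:
compound 1 `CC/C(=C(/c1ccc(/C=C/C(=O)O)cc1)c1cc2ccccc2[nH]1)c1ccccc1C(F)(F)F` — 8 nM
compound 2 `CC/C(=C(/c1ccc(/C=C/C(=O)O)cc1)c1cc2ccccc2[nH]1)c1ccccc1OC(F)(F)F` — 206 nM

For the measured compounds named here, compound 2 stands at the higher of the two numbers in this assay, and its only neighbour is compound 1, which gives 8 nM. Going by the values given here, the single measured step between them, a 26-fold higher number from compound 1 to compound 2 (1.41 log units; beyond the scatter), is the only guide available: swapping trifluoromethyl for trifluoromethoxy on the aromatic carbon cost a great deal of inhibition.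

Compound 3 `CC/C(=C(/c1ccc(/C=C/C(=O)O)cc1)c1cc2ccccc2[nH]1)c1cccc(C(F)(F)F)c1` has not yet been measured. It differs from compound 2 by 3-(trifluoromethyl)phenyl in place of 2-(trifluoromethoxy)phenyl on a double-bonded chain carbon bound to a double-bonded chain carbon and a saturated chain carbon. This change puts a trifluoromethyl group back in place of the trifluoromethoxy group, but it also moves that group to a different aromatic carbon, so the measured step does not carry over directly. Among the compounds with values here, because a 26-fold higher number from compound 1 to compound 2 (1.41 log units; beyond the scatter) was large, the return to trifluoromethyl argues for a clearly lower number; the shift in position, for which no measured compound exists, leaves the size open. The expected step is therefore a 5.2-fold lower number from compound 2 to compound 3 (0.71 log units; beyond the scatter), a lowering beyond the scatter. Compound 3 is estimated at 40 nM, with a range from 8 nM to 200 nM.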

Compound 3, half-maximal inhibitory concentration: 325 nM
For compound 3 the middle estimate is 8.1-fold (0.91 log units) below the measured one; the measured number lies above the stated range.
By their numbers in this assay, from the lowest: compound 1; then compounds 2 and 3 (each within the scatter of the next).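

With trifluoromethyl kept and only its place on the aromatic ring altered, 3-(trifluoromethyl)phenyl in place of 2-(trifluoromethyl)phenyl gives a 41-fold higher number from compound 1 to compound 3 (1.61 log units; beyond the scatter) in this assay, so the group's name alone does not decide the outcome at this double-bonded chain carbon; where it stands on the ring counts as well. The direct exchange of 2-(trifluoromethoxy)phenyl for 3-(trifluoromethyl)phenyl gives a 1.6-fold higher number from compound 2 to compound 3 (0.20 log units; within the scatter), so the two departures from 2-(trifluoromethyl)phenyl end at numbers that cannot be told apart, and among the three compounds only compound 1 reaches the low range. Nothing measured here accounts for this sensitivity to the substituent and its location.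

The compounds shown leave open whether a methyl group or a chlorine atom in place of the trifluoromethyl of 2-(trifluoromethyl)phenyl would keep a number close to that of compound 1 at 8 nM, or whether that value depends on trifluoromethyl itself. They also leave open how trifluoromethoxy would fare on the aromatic carbon that carries trifluoromethyl in 3-(trifluoromethyl)phenyl.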